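A few compounds are considered here, and "the series" means these few. Any claim that something is new, unique, unknown or untested is made for them only; others in the source may bear on it.

Compound 1, `Cc1ccnc(NC(c2ccc3cccnc3c2O)c2c(Cl)cccc2Cl)c1`, carries a methyl group and a 2,6-dichlorophenyl group on its shared core. In an assay for inhibition of protein disulfide-isomerase (Homo sapiens), with a stated time of 1 h (a lower number here means a stronger inhibitor, a higher number a weaker inhibitor), compound 1 reaches only the limit of the assay, > 40000 nM, which is a limit rather than a measured number. Compound 2, `Oc1c(C(Nc2ccccn2)c2c(Cl)cccc2Cl)ccc2cccnc12`, differs from compound 1 by hydrogen in place of methyl on an aromatic carbon, and in this assay compound 2 gives 1890 nM. That step is an at least 21-fold lower number from compound 1 to compound 2 (1.32 log units; beyond the scatter); it rests on (the limit of > 40000 nM in this assay, at which 1 of the 2 values shown sits), so its true size is open-ended. Compound 3, `Cc1ccnc(NC(c2ccccc2F)c2ccc3cccnc3c2O)c1`, keeps the methyl of compound 1 and differs from it in one place: 2-fluorophenyl in place of 2,6-dichlorophenyl on a saturated chain carbon bound to an aromatic carbon and a nitrogen on an aromatic ring. Going by the values given here, no measured step touches the 2,6-dichlorophenyl group; the single measured step concerns the methyl, which compound 3 retains, so nothing measured here bears directly on this change. The number for compound 3 is therefore estimated to sit close to where compound 1 stands, with a wide range and a real chance that only a limit is reported again. Compound 3 is expected at 40000 nM, between 8000 nM and 200000 nM. This amounts to an expected step of a number no higher from compound 1 to compound 3 (the limit leaves the size open).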

Compound 3, half-maximal inhibitory concentration: 880 nM
Beside the measured number, compound 3's estimate is 45-fold (1.66 log units) above it; the whole stated range lies above it.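

Replacing 2,6-dichlorophenyl with 2-fluorophenyl on the saturated chain carbon gives an at least 45-fold lower number from compound 1 to compound 3 (1.65 log units; beyond the scatter). Going by these compounds alone, until now, the only measured step was the loss of the methyl group, which could have suggested that the methyl alone kept compound 1 out of measurable range. Compound 3 keeps that methyl yet gives a measured number, so the methyl alone does not hold a compound at the limit, and the aromatic group at this second place also has a large bearing on the result; the full size of the step stays open, as compound 1 gives only a limit: the limit of > 40000 nM in this assay, at which 1 of the 3 values shown sits.

The change removes the chlorines and adds a fluorine in a single move, so the compounds shown cannot tell whether losing chlorine, gaining fluorine or both matter, and a plain phenyl or a 2-chlorophenyl group at this place would help to separate these. It also remains open whether removing the methyl and making this aromatic swap would work together on the same core, as no compound shown carries both changes.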